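Cytotoxicity limits on the shared core: compound 4 estimate

A few compounds are considered here, and "the series" means these few. Any claim that something is new, unique, unknown or untested is made for them only; others in the source may bear on it.

Measured compounds:
compound 1 `Nc1nc(NC2CC2)c2ncn(/C=C3/CC3(CO)CO)c2n1` — > 300000 nM
compound 2 `CCCCCCCCSc1nc(N)nc2c1ncn2/C=C1/CC1(CO)CO` — > 300000 nM
compound 3 `CCCCCCOc1nc(N)nc2c1ncn2/C=C1/CC1(CO)CO` — > 200000 nM

In an ADME assay on HFF cells (Homo sapiens) for cytotoxicity, with a stated time of 8 days (a lower number here means that less compound is tolerated, a higher number that more compound is tolerated), compound 1 gives only a limit, > 300000 nM. Compound 2 likewise gives only a limit, > 300000 nM. Compound 3 also gives only a limit, > 200000 nM. All three values therefore sit at limits, two of them at the limit of > 300000 nM in this assay, at which 2 of the 3 values shown sit, and one at the limit of > 200000 nM in this assay, at which 1 of the 3 values shown sits, and compound 1 cannot be placed above or below the others.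

The change to compound 4 `Nc1nc(SCc2ccccc2)c2ncn(/C=C3/CC3(CO)CO)c2n1` is benzylsulfanyl in place of cyclopropylamino on an aromatic carbon. Among the compounds with values here, the steps that bear on it are a step that the two limits leave unreadable from compound 1 to compound 2 and a step that the two limits leave unreadable from compound 1 to compound 3, both also unreadable, and a step that the two limits leave unreadable from compound 2 to compound 3 gives nothing further. Every replacement at this carbon so far has left the read-out at a limit, so no step beyond the scatter is expected in this assay in either direction, and the result for compound 4 is expected most likely to be a limit again.

Compound 4 is therefore estimated at 300000 nM, between 100000 nM and 1000000 nM. The step of a number no higher from compound 1 to compound 4 (the limit leaves the size open) is expected to be unreadable in the same way.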

Compound 4, half-maximal cytotoxic concentration: > 300000 nM
Compound 4: only a limit was reported (the forecaster's own chance of this, stated with the estimate: 80%); the middle value lies on the limit itself.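

In this assay compound 4 gives > 300000 nM, which is a limit. Within the data shown here, no step between compound 4 and compound 1, compound 2 or compound 3 can be read. The compounds shown leave open at what concentration any of the four becomes cytotoxic, and whether the replacements on this aromatic carbon change that concentration.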